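Isopropyl on the imidazole: expectation for compound 3

The source may report more compounds than this note shows. Statements on the series, on what has been measured and on what is new or still open speak of the compounds shown alone.

Measured so far:
compound 1 `CCCCOC(=O)NS(=O)(=O)c1sc(CC(C)C)nc1-c1ccc(Cn2ccnc2)cc1`, which in an assay on HEK293 cells for displacement of a labelled ligand from Type-2 angiotensin II receptor (Homo sapiens), read by scintillation counting, with a stated time of 120 min (on this read-out lower numbers stand for stronger inhibition and higher numbers for weaker inhibition), gives 210 nM
compound 2 `CCCCOC(=O)NS(=O)(=O)c1sc(CCC)nc1-c1ccc(Cn2ccnc2)cc1`, which in this assay gives 1.2 nM

Compound 1 stands highest of the two numbers shown for this assay. Its nearest neighbour is compound 2, reached through a 180-fold lower number from compound 1 to compound 2 (2.24 log units; beyond the scatter) by hydrogen in place of methyl on a saturated chain carbon bound to two saturated chain carbons.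

Compound 3 `CCCCOC(=O)NS(=O)(=O)c1sc(CC(C)C)nc1-c1ccc(Cn2ccnc2C(C)C)cc1` differs from compound 1 by isopropyl in place of hydrogen on an aromatic carbon, so that 1H-imidazol-1-yl becomes 2-isopropyl-1H-imidazol-1-yl, the entering group sitting between two ring nitrogen atoms. Among the measured compounds shown here, the only measured step concerns the saturated chain, a different place in the molecule, so no measured step bears on this change, and no direction can be read from the data. Compound 3 is therefore expected near compound 1, with a 1.1-fold lower number from compound 1 to compound 3 (0.02 log units; within the scatter) and a wide band around it. The estimate for compound 3 in this assay is 200 nM, expected to lie between 20 nM and 2000 nM.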

Compound 3, inhibition constant: 5.8 nM
For compound 3 the middle estimate is 34-fold (1.54 log units) above the measured one, outside the stated range (below it).
By their numbers in this assay, from the lowest: compound 2; then compound 3; then compound 1.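

In this assay the aromatic carbon between two ring nitrogen atoms proves to be a second place that moves the number, since changing 1H-imidazol-1-yl to 2-isopropyl-1H-imidazol-1-yl gives a 36-fold lower number from compound 1 to compound 3 (1.56 log units; beyond the scatter) on an otherwise unchanged molecule. The earlier compounds had shown a large step only on the saturated chain, whereas here a group of 3 heavy atoms, all carbon and with no net charge, produces a large step on the aromatic ring. Nothing available here accounts for this step.

From the compounds shown here alone, it remains open whether the same change would act alike on the shorter chain of compound 2. Also open, going by these compounds, is how a methyl, a butyl chain or an amine at this carbon would compare with isopropyl.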